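Efficacy of amide variants at free fatty acid receptor 2

The compounds below may be only part of what the source reports. "The series", "measured", "known", "first", "only" and "open" are said of these compounds alone.

Measured in a functional assay on CHO cells for agonist activity at Free fatty acid receptor 2 (Homo sapiens), read by cAMP accumulation; on this read-out higher numbers stand for larger maximal responses and lower numbers for smaller maximal responses:
- compound 1 `CNC(=O)[C@H](c1ccc(Cl)cc1)C(C)C` gives 66%
- compound 2 `CC(C)C(C(=O)Nc1ncccn1)c1ccc(Cl)cc1` gives 50%
- compound 3 `CC(C)[C@H](C(=O)Nc1ncc[nH]1)c1ccc(Cl)cc1` gives 55%

Compound 2 shows the lowest of the three numbers in this assay; compound 3 lies within the scatter of it, while compound 1 stands higher beyond the scatter. Compound 4 `CC(C)C(C(=O)Nc1nnn[nH]1)c1ccc(Cl)cc1` is not yet measured. Its change from compound 2: 1H-tetrazol-5-yl in place of pyrimidin-2-yl on an amide-type nitrogen. Going by the values given here, the only measured step, a number 11 percentage points lower from compound 1 to compound 3 (beyond the scatter), concerns imidazolyl entering for methyl and does not cover an exchange of one heteroaryl for another; the two heteroaryl amides, compound 2 and compound 3, differ within the scatter. Compound 4 is therefore expected to shift by a number 2 percentage points higher from compound 2 to compound 4 (within the scatter), nothing beyond the scatter. Compound 4 is estimated at 52%, with a range of 35% to 68%.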

Compound 4, largest response reached (reported as efficacy), in percent of the reference or control that the assay uses: < 30%
Compound 4: no number, only a limit (the forecaster's own chance of this, stated with the estimate: 5%); middle value at least 22 percentage points away from the limit.
By their numbers in this assay, from the lowest: compounds 2 and 3 (each within the scatter of the next); then compound 1. At a limit, below all of these: compound 4.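

The heteroaryl group on the amide-type nitrogen is not freely exchangeable: 1H-tetrazol-5-yl in place of pyrimidin-2-yl gives a number at least 20 percentage points lower from compound 2 to compound 4 (beyond the scatter) in this assay. Going by these compounds alone, the earlier heteroaryl amides, compound 2 and compound 3, lay within the scatter of each other and gave no sign of a step of this size from a change of ring alone. Compound 4 has no number, only a limit: the limit of < 30% in this assay, at which 1 of the 4 values shown sits.

From the compounds shown here alone, how far compound 4 truly lies under that limit stays open. Also open, going by these compounds, is whether a carboxylic acid or an amine at this place would track with compound 4 or with compound 2.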